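The source may report more compounds than this note shows. Statements on the series, on what has been measured and on what is new or still open speak of the compounds shown alone.

In a functional assay on KB cells (Homo sapiens) for cytotoxicity, read by MTT assay, with a stated time of 3 days (on this read-out higher numbers stand for weaker inhibition and lower numbers for stronger inhibition), compound 1 `N#Cc1c(-c2ccccc2)nc(SCc2nc3ccccc3[nH]2)nc1N1CCNCC1` gives 2.87 nM and compound 2 `CN1CCN(c2nc(SCc3nc4ccccc4[nH]3)nc(-c3ccccc3)c2C#N)CC1` gives 2.7 nM, so compound 2 stands level with compound 1. Compound 3 `N#Cc1c(-c2ccccc2)nc(SCc2nc3ccccc3[nH]2)nc1N1CCN(S(=O)(=O)c2ccccc2)CC1` differs from compound 2 by phenylsulfonyl in place of methyl on an amine nitrogen in a ring, with phenylsulfonyl in place of methyl on an amine nitrogen in a ring. Among the compounds with values here, the only measured step at this nitrogen, a 1.1-fold lower number from compound 1 to compound 2 (0.03 log units; within the scatter), lies within the scatter, but it covers only methyl in place of hydrogen and is a weak guide to this bigger exchange. A modest move towards a higher number is therefore expected, namely a 2.2-fold higher number from compound 2 to compound 3 (0.35 log units; beyond the scatter). For compound 3 the estimated value is 6 nM, with an expected range of 1.5 nM to 30 nM.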

Compound 3, half-maximal inhibitory concentration: 3 nM
Compound 3: the middle estimate sits 2.0-fold (0.30 log units) above what was measured, and the stated range covers the measured number.
By their numbers in this assay, from the lowest: compounds 2, 1 and 3 (each within the scatter of the next).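

Phenylsulfonyl on the amine nitrogen in the ring, with its 9 heavy atoms and one six-membered aromatic ring, leaves the number level: a 1.1-fold higher number from compound 2 to compound 3 (0.05 log units; within the scatter), and a 1.0-fold higher number from compound 1 to compound 3 (0.02 log units; within the scatter). Within the data shown here, this nitrogen, previously seen only with hydrogen and methyl, thus takes a much larger group with no step beyond the scatter. No measurement at hand bears on this result. From the compounds shown here alone, whether a carboxylic acid or a longer chain on this nitrogen would also stay level remains open, as does the effect of changes elsewhere on the shared core.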